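The source may report more compounds than this note shows. Statements on the series, on what has been measured and on what is new or still open speak of the compounds shown alone.

Working notes on the series. Compound 1 `CC1(C)C=C(n2ccccc2=O)c2cc(C(=O)c3ccc(O)cc3)ccc2O1` gives in a functional assay (trachea) with Rattus norvegicus as the target (a lower number here means a less potent compound, a higher number a more potent compound, by a factor of ten per unit of this negative logarithm), a reading of 5.87, the highest of the two numbers recorded so far; the nearest is compound 2 `CC1(C)C=C(n2ccccc2=O)c2cc(C(=O)c3ccccc3[N+](=O)[O-])ccc2O1`, which in this assay gives 5.64, with a number 0.23 log units lower from compound 1 to compound 2 (within the scatter). That single step only exchanges one aryl group for another on the carbonyl carbon.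

Compound 3 `CC1(C)C=C(n2ccccc2=O)c2cc(OS(=O)(=O)F)ccc2O1` differs from compound 1 in another way: (fluorosulfonyl)oxy in place of (4-hydroxyphenyl)carbonyl on an aromatic carbon. A whole aromatic ring with its carbonyl leaves, and (fluorosulfonyl)oxy enters on the same aromatic carbon. Among the compounds with values here, no measured step covers a change of this kind; the step from compound 1 to compound 2 shows only that two aryl groups on the carbonyl carbon read alike. With (4-hydroxyphenyl)carbonyl removed entirely, a fall beyond the scatter is expected, its size uncertain.

Compound 3 is therefore expected to show a number 0.67 log units lower from compound 1 to compound 3 (beyond the scatter). For compound 3 the estimate in this assay is 5.2, in a range from 4.5 to 5.9.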

Compound 3, logarithm of the reciprocal of the active concentration, log(1/C): 7.22
Beside the measured number, compound 3's estimate is 2.02 log units below it, and the stated range ends below it.
By their numbers in this assay, from the lowest: compounds 2 and 1 (each within the scatter of the next); then compound 3.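

The step to (fluorosulfonyl)oxy moves the reading far more than the aryl exchange on the carbonyl carbon did, with a number 1.35 log units higher from compound 1 to compound 3 (beyond the scatter) in this assay. The (4-hydroxyphenyl)carbonyl group, with its aromatic ring and carbonyl, is therefore not required for a high reading at this aromatic carbon, and a group with no ring, fewer heavy atoms and no hydrogen-bond donor reads well there. No measurement shown accounts for the rise.

This single step cannot separate the loss of (4-hydroxyphenyl)carbonyl from the arrival of (fluorosulfonyl)oxy. As far as these compounds go, whether the high reading is particular to (fluorosulfonyl)oxy, or would also appear with a nitrile, a methanesulfonyl group or an amine on the same aromatic carbon, remains open.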